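A few compounds are considered here, and "the series" means these few. Any claim that something is new, unique, unknown or untested is made for them only; others in the source may bear on it.

Of the compounds shown here, three sharing one core have been measured in a functional assay on GOTO cells (Homo sapiens) for cytotoxicity, read by MTT assay, with a stated time of 3 days; a lower number here means a stronger inhibitor, a higher number a weaker inhibitor. Compound 1 `N#Cc1c(-c2ccccc2)nc(SCc2nc3ccccc3[nH]2)nc1N1CCNCC1`, which has hydrogen on an amine nitrogen in a ring, gives 3.7 nM. Compound 2 `CN1CCN(c2nc(SCc3nc4ccccc4[nH]3)nc(-c3ccccc3)c2C#N)CC1`, with methyl at that nitrogen, gives 3.37 nM. Compound 3 `Cc1ccc(S(=O)(=O)N2CCN(c3nc(SCc4nc5ccccc5[nH]4)nc(-c4ccccc4)c3C#N)CC2)cc1`, with (4-methylphenyl)sulfonyl there, gives 4.38 nM. Compound 3 therefore stands level with the other two, as its gaps to both lie within the usual scatter of repeated measurements.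

Compound 4 `N#Cc1c(-c2ccccc2)nc(SCc2nc3ccccc3[nH]2)nc1N1CCN(S(=O)(=O)c2ccccc2[N+](=O)[O-])CC1` has not yet been measured. It differs from compound 3 on one group: 2-nitrophenyl in place of 4-methylphenyl on a sulfonyl sulfur. Put simply, 2-nitrophenyl takes the place of 4-methylphenyl on a sulfonyl sulfur. Among the compounds with values here, no measured pair tests a swap at that spot, and no measured compound carries 2-nitrophenyl, so the evidence is only indirect. The closest guides are the steps at the ring nitrogen: a 1.1-fold lower number from compound 1 to compound 2 (0.04 log units; within the scatter), a 1.2-fold higher number from compound 1 to compound 3 (0.07 log units; within the scatter) and a 1.3-fold higher number from compound 2 to compound 3 (0.11 log units; within the scatter). All three lie within the scatter, so no step beyond the scatter is expected here, although the range must stay wide for an untested group. The expected step is a 1.1-fold lower number from compound 3 to compound 4 (0.04 log units; within the scatter). The estimate for compound 4 is 4 nM, with an expected range from 1.5 nM to 12 nM.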

Compound 4, half-maximal inhibitory concentration: 3 nM
Estimate against measurement, compound 4: 1.3-fold (0.12 log units) above, within the range that was stated.
By their numbers in this assay, from the lowest: compounds 4, 2, 1 and 3 (each within the scatter of the next).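

In this assay, within the data shown here, the first change on the aryl group at the sulfonyl sulfur, 2-nitrophenyl in place of 4-methylphenyl, gives a 1.5-fold lower number from compound 3 to compound 4 (0.16 log units; within the scatter), so swapping this aryl group for one that contains nitrogen and oxygen, and carries hydrogen-bond acceptors, leaves the result level. The comparisons at the ring nitrogen agree: (2-nitrophenyl)sulfonyl in place of methyl gives a 1.1-fold lower number from compound 2 to compound 4 (0.05 log units; within the scatter), and in place of hydrogen it gives a 1.2-fold lower number from compound 1 to compound 4 (0.09 log units; within the scatter), so four different groups on that nitrogen now stand level across these four compounds. No separate measurement of any property bears on this result.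

Still open, as far as these compounds go, is whether a phenyl on the sulfonyl sulfur that carries a carboxylic acid or an amine, or an acetyl group directly on the ring nitrogen, would also stay level with these compounds. The rest of the shared core is identical in all four compounds, so these data cannot say how the number would respond if the nitrile or the phenyl on the core were replaced, for example with an amide or a pyridine.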